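Methyl to trifluoromethyl on the five-membered ring

The source may report more compounds than this note shows. Statements on the series, on what has been measured and on what is new or still open speak of the compounds shown alone.

Compound 1 `COc1ccc(-n2cnnn2)cc1CO[C@H]1CCCN[C@H]1c1ccccc1` gives 0.05 nM in an assay on HEK293 cells (Gerbillinae) for displacement of a labelled ligand from Substance-P receptor (Meriones unguiculatus), read by scintillation counting, with a stated time of 30 min; a lower number here means a stronger inhibitor, a higher number a weaker inhibitor. Compound 2 `COc1ccc(-n2nnnc2C)cc1CO[C@H]1CCCN[C@H]1c1ccccc1`, carrying a methyl in place of hydrogen on an aromatic carbon, gives 0.05 nM in this assay. The single measured step, no change at the digits printed from compound 1 to compound 2 (within the scatter), shows that this position accepts a small group without any change at the digits shown. Compound 2 therefore stands level with compound 1 at the digits shown, within the scatter, and there is no order to speak of between the two.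

Compound 3 `COc1ccc(-n2nnnc2C(F)(F)F)cc1CO[C@H]1CCCN[C@H]1c1ccccc1` differs from compound 2 by trifluoromethyl in place of methyl on an aromatic carbon. Among the compounds with values here, the only measured step that bears on this position is no change at the digits printed from compound 1 to compound 2 (within the scatter), and it was flat. Within the data shown here, no measured step covers a trifluoromethyl anywhere, so the size of any effect of the trifluoromethyl itself is unknown from these data. The working expectation is accordingly no step beyond the scatter, a 1.2-fold higher number from compound 2 to compound 3 (0.08 log units; within the scatter), with a range widened to allow for the untested group. Compound 3 is expected to give 0.06 nM in this assay, within 0.02 nM to 0.25 nM.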

Compound 3, half-maximal inhibitory concentration: 0.03 nM
The estimate for compound 3 lay 2.0-fold (0.30 log units) above the measured number; low and high end bracket the measured number.
By their numbers in this assay, from the lowest: compounds 3, 1 and 2 (each within the scatter of the next).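

On the aromatic carbon between two ring nitrogen atoms, trifluoromethyl, with 4 heavy atoms against 1 for methyl, is accepted in this assay, with a 1.7-fold lower number from compound 2 to compound 3 (0.22 log units; within the scatter). Measured against hydrogen at the same carbon, the reading is a 1.7-fold lower number from compound 1 to compound 3 (0.22 log units; within the scatter), so hydrogen, methyl and trifluoromethyl all lie within the scatter of one another and the flat reading now extends beyond a single small group. Nothing available accounts for this flat reading.

As far as these compounds go, whether the same carbon also accepts an amine, a carboxylic acid, a longer chain or a phenyl ring remains open, so the limit of what this position accepts is not yet defined. All three readings come from this assay, which leaves open how hydrogen, methyl and trifluoromethyl at this carbon compare in any other measurement.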